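Adding a Ring Hydroxy to Compound 3

This account rests on a few compounds, and the source may have more. Where it says the series, first, only, none or still open, it means among the compounds named here.

In a functional assay on KB cells (Homo sapiens) for cytotoxicity, read by colorimetric assay and neutral red uptake, with a stated time of 72 h (on this read-out lower numbers stand for stronger inhibition and higher numbers for weaker inhibition), compound 3 `CO[C@@H](C(=O)N[C@@H]1CCCCNC1=O)[C@H](O)[C@@H](O)[C@H](O)/C=C/C(C)(C)C` gives 1100 nM, the lowest number measured here, against compound 2 `CO[C@@H](C(=O)N[C@H]1CC[C@@H](O)CNC1=O)[C@H](O)[C@@H](O)[C@H](O)/C=C/C(C)(C)C` at 62600 nM. Compound 1 `CO[C@@H](C(=O)N[C@H]1CCCCNC1=O)[C@@H]1OC(C)(C)O[C@H](/C=C/C(C)(C)C)[C@@H]1O` gives > 150000 nM, which is a limit of this assay. Compound 4 `CO[C@@H](C(=O)N[C@@H]1CC[C@@H](O)CNC1=O)[C@H](O)[C@@H](O)[C@H](O)/C=C/C(C)(C)C` has hydroxy in place of hydrogen on a saturated ring carbon of compound 3 (hydroxy in place of hydrogen on a saturated ring carbon). Among the compounds with values here, one measured step bears on this: a 57-fold lower number from compound 2 to compound 3 (1.76 log units; beyond the scatter), where the hydroxy is absent from the product. Read in reverse, it suggests a higher number for compound 4, but a single step is a thin guide, so a somewhat smaller size is expected. The expected change is an 18-fold higher number from compound 3 to compound 4 (1.26 log units; beyond the scatter). For compound 4 the estimated value is 20000 nM, with an expected range of 3000 nM to 100000 nM.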

Compound 4, half-maximal inhibitory concentration: 5100 nM
The estimate for compound 4 lay 3.9-fold (0.59 log units) above the measured number; low and high end bracket the measured number.
By their numbers in this assay, from the lowest: compound 3; then compound 4; then compound 2. At a limit, above all of these: compound 1.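

In this assay, adding the hydroxy to the ring carbon gives only a modest loss, a 4.6-fold higher number from compound 3 to compound 4 (0.67 log units; beyond the scatter), so a number of the same order remains possible with this group present. Configuration matters more here, with a large step of a 12-fold lower number from compound 2 to compound 4 (1.09 log units; beyond the scatter). That step can be assigned to stereochemistry alone because of one fact about this pair: the fact that compounds 2 and 4 differ only in the configuration as drawn. From the compounds shown here alone, whether an amine or a methoxy group on this ring carbon would behave like the hydroxy remains open. So does the effect of a hydroxy on other carbons of the ring.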